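Ortho substituent variation on the benzyl group of the series

The source may report more compounds than this note shows. Statements on the series, on what has been measured and on what is new or still open speak of the compounds shown alone.

Compound 3 `Cc1c(Cc2ccccc2C(=O)c2ccccc2)c2c(n1CC(=O)O)CCNC2=O` sits at the weak end of the three measured analogues: in a functional assay on CHO.K1 cells for antagonist activity at prostaglandin D2 receptor 2 (Homo sapiens), read by GTPgammaS binding, with a stated time of 1 h (on this read-out higher numbers stand for weaker inhibition and lower numbers for stronger inhibition), compound 3 gives 810 nM, which is the highest number among them. Compound 2 `Cc1c(Cc2ccccc2Cn2ccnn2)c2c(n1CC(=O)O)CCNC2=O` gives 800 nM, and a 1.0-fold higher number from compound 2 to compound 3 (0.01 log units; within the scatter). Compound 1 `Cc1c(Cc2ccccc2S(=O)(=O)N2CCOCC2)c2c(n1CC(=O)O)CCNC2=O` gives 22 nM; a 36-fold higher number from compound 1 to compound 2 (1.56 log units; beyond the scatter) and a 37-fold higher number from compound 1 to compound 3 (1.57 log units; beyond the scatter), so the morpholinosulfonyl analogue stands apart from the other two.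

Compound 4 `Cc1c(Cc2ccccc2-c2cccc3ccccc23)c2c(n1CC(=O)O)CCNC2=O` differs from compound 3 by naphthalen-1-yl in place of benzoyl on an aromatic carbon. Within the data shown here, no measured step covers this exact exchange. The nearest reference is a 1.0-fold higher number from compound 2 to compound 3 (0.01 log units; within the scatter), which shows that swapping one ortho group for another left the number essentially unchanged once the morpholinosulfonyl group was gone. On that basis the step of a 1.1-fold higher number from compound 3 to compound 4 (0.05 log units; within the scatter) is expected to stay within the scatter, with no clear direction. Compound 4 is therefore estimated at 900 nM in this assay, with a range from 250 nM to 3000 nM.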

Compound 4, half-maximal inhibitory concentration: 480 nM
The estimate for compound 4 lay 1.9-fold (0.27 log units) above the measured number; the range from low to high includes it.
By their numbers in this assay, from the lowest: compound 1; then compounds 4, 2 and 3 (each within the scatter of the next).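

In this assay, naphthalen-1-yl on this aromatic carbon, ortho to a large group, carries no hydrogen-bond acceptor, unlike benzoyl, yet the exchange gives a 1.7-fold lower number from compound 3 to compound 4 (0.23 log units; within the scatter), and against (1H-1,2,3-triazol-1-yl)methyl it gives a 1.7-fold lower number from compound 2 to compound 4 (0.22 log units; within the scatter). Three different groups at this position, including one made of carbon only, therefore remain unseparated, while the (morpholin-4-yl)sulfonyl group of compound 1 still stands apart, with a 22-fold higher number from compound 1 to compound 4 (1.34 log units; beyond the scatter). No supporting data bear on why this position responds in this way.

The compounds shown leave open whether the difference follows the sulfonyl unit or the morpholine ring. Methylsulfonyl, dimethylaminosulfonyl, piperidin-1-ylsulfonyl and morpholine-4-carbonyl at this position would separate those two parts.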